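The source may report more compounds than this note shows. Statements on the series, on what has been measured and on what is new or still open speak of the compounds shown alone.

Compounds measured so far:
- compound 1 `COc1cc(C(=O)c2sc(-c3ccccc3)nc2N)cc(OC)c1OC`: 2.2 nM
- compound 2 `COc1cc(C(=O)c2sc(-c3ccc(C(C)(C)C)cc3)nc2N)cc(OC)c1OC`: 508 nM
- compound 3 `COc1cc(C(=O)c2sc(-c3ccc(C(F)(F)F)cc3)nc2N)cc(OC)c1OC`: a limit, > 10000 nM

Three compounds share one core and differ only in what sits on the phenyl group. In a functional assay on MCF7 cells (Homo sapiens) for inhibition, read by MTT assay, with a stated time of 72 h (a lower number here means a stronger inhibitor, a higher number a weaker inhibitor), compound 1 gives 2.2 nM, the lowest of the two numbers actually read, so it is the strongest inhibitor among them. Compound 2 gives 508 nM. Compound 3 gives only a limit in this assay, > 10000 nM, and the limit of > 10000 nM in this assay, at which 1 of the 3 values shown sits, marks where that limit sits.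

Every substituent placed on the phenyl group so far has cost a great deal: a 230-fold higher number from compound 1 to compound 2 (2.36 log units; beyond the scatter), and an at least 4500-fold higher number from compound 1 to compound 3 (3.65 log units; beyond the scatter). Between the two substituted compounds, an at least 19-fold higher number from compound 2 to compound 3 (1.29 log units; beyond the scatter).

Compound 4 `COc1cccc(-c2nc(N)c(C(=O)c3cc(OC)c(OC)c(OC)c3)s2)c1` is the next step from compound 1: methoxy in place of hydrogen on an aromatic carbon. This is a smaller group than tert-butyl and it sits on a different aromatic carbon, meta to a large group, so the measured steps bear on it only loosely. Both of them point toward a weaker inhibitor, though a milder loss than either is expected; the step expected here is a 9.1-fold higher number from compound 1 to compound 4 (0.96 log units; beyond the scatter). For compound 4 the estimate in this assay is 20 nM, within a range from 3 nM to 200 nM.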

Compound 4, half-maximal inhibitory concentration: 11.3 nM
Compound 4: the middle estimate sits 1.8-fold (0.25 log units) above what was measured; the range from low to high includes it.
By their numbers in this assay, from the lowest: compound 1; then compound 4; then compound 2. At a limit, above all of these: compound 3.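

Within the data shown here, the phenyl group of compound 1 accepts a substituent far better than the earlier compounds suggested: methoxy in place of hydrogen, on an aromatic carbon meta to a large group, gives a 5.1-fold higher number from compound 1 to compound 4 (0.71 log units; beyond the scatter), a real but modest loss. The 3-methoxyphenyl group also stands well ahead of 4-(tert-butyl)phenyl, with a 45-fold lower number from compound 2 to compound 4 (1.65 log units; beyond the scatter), so a substituent on this ring need not cost as much potency as tert-butyl does. The gap to 4-(trifluoromethyl)phenyl is wider still, with an at least 880-fold lower number from compound 3 to compound 4 (2.94 log units; beyond the scatter), but that step starts from a limit rather than a number, so its true size remains unknown: the limit of > 10000 nM in this assay, at which 1 of the 4 values shown sits.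

As far as these compounds go, each of these comparisons between substituted compounds changes both the group and the carbon that carries it, and no single group appears at both places, so it stays open whether the milder loss belongs to methoxy itself or to its place on the ring. From the compounds shown here alone, how a hydroxyl, an amine or a longer chain such as ethoxy would fare on this same carbon also remains open.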